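Shortening the chain on the nitrogen of compound 2

A few compounds are considered here, and "the series" means these few. Any claim that something is new, unique, unknown or untested is made for them only; others in the source may bear on it.

Of the compounds shown here, three sharing one core have been measured in an assay on cell membranes from brain for binding affinity to adenosine receptor A1 (Rattus norvegicus), read by radioligand binding; on this read-out lower numbers stand for stronger inhibition and higher numbers for weaker inhibition. Compound 1 `CCCn1c(=O)[nH]c2ncn(C)c2c1=O` gives 21000 nM. Compound 2 `C#CCn1c(=O)[nH]c2[nH]c(-c3ccccc3)nc2c1=O` gives 210 nM, and compound 3 `C#CCn1c(=O)[nH]c2[nH]c(C3CCCCC3)nc2c1=O` gives 170 nM. Compound 2 therefore stands second highest of the three numbers: its nearest neighbour is compound 3, reached by a 1.2-fold lower number from compound 2 to compound 3 (0.09 log units; within the scatter), a step made by putting cyclohexyl in place of phenyl on an aromatic carbon, while the furthest is compound 1, whose number is far higher and beyond the scatter.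

Compound 4 `Cn1c(=O)[nH]c2[nH]c(-c3ccccc3)nc2c1=O` has not yet been measured. It differs from compound 2 by hydrogen in place of ethynyl on a saturated chain carbon bound to an aromatic nitrogen; cut one bond further out, the same change reads propargyl to methyl. No measured step touches this position: the only shown step, from compound 2 to compound 3, alters an aromatic carbon and leaves the chain on the nitrogen untouched, and compound 1 differs from compound 4 in more than one place, so its value alone cannot be assigned to this change. The data therefore give no direct guide, and the expectation rests on the size of what is removed. Losing the two-carbon ethynyl is expected to weaken binding, a step of a 3.8-fold higher number from compound 2 to compound 4 (0.58 log units; beyond the scatter). Compound 4 is thus estimated at 800 nM, within a range from 200 nM to 3000 nM.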

Compound 4, inhibition constant: 260 nM
Compound 4: the middle estimate sits 3.1-fold (0.49 log units) above what was measured, and the stated range covers the measured number.
By their numbers in this assay, from the lowest: compounds 3, 2 and 4 (each within the scatter of the next); then compound 1.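

Among the compounds shown here, compound 4 gives the first reading at this position, since the only earlier step, a 1.2-fold lower number from compound 2 to compound 3 (0.09 log units; within the scatter), changed a group on an aromatic carbon and left the chain on the nitrogen as it was. In this assay, putting hydrogen in place of ethynyl on a saturated chain carbon bound to an aromatic nitrogen gives a 1.2-fold higher number from compound 2 to compound 4 (0.09 log units; within the scatter), so the change from propargyl to methyl, which removes the triple bond, cannot be told apart from repeat-measurement noise with the phenyl group in place. Nothing shown here explains this result.

From the compounds shown here alone, the two compounds span only propargyl and methyl, so it remains open whether a longer chain such as butyl, or a chain ending in an amine or a carboxylic acid, would stay equally close to compound 2. The pair also carries phenyl on both sides, which leaves open whether the same change would give so small a step with cyclohexyl in that place.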